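Sulfonyl aryl substituent: fluoro to cyano

The source may hold more compounds than are shown below. What is called first, only, known or untested is meant among the compounds shown, and "the series" means these compounds.

Measured so far in an assay on isolated protein for displacement of a labelled ligand from metabotropic glutamate receptor 5 (Homo sapiens), with a stated time of 60 min, tested at 1 uM; on this read-out higher numbers stand for more inhibition at the one concentration tested (going by the name of the read-out) and lower numbers for less inhibition:
compound 1 `CC1CCN(c2c(S(=O)(=O)c3cc(Cl)cc(Cl)c3)cnc3ccc(F)cc23)CC1` — 69%
compound 2 `COc1cccc(S(=O)(=O)c2cnc3ccc(F)cc3c2N2CCC(C)CC2)c1` — 90%
compound 3 `CC1CCN(c2c(S(=O)(=O)c3cccc(F)c3)cnc3ccc(F)cc23)CC1` — 76%

Compound 3 stands second highest of the three numbers in this assay. Its nearest neighbour is compound 1, with a number 7 percentage points higher from compound 1 to compound 3 (within the scatter), a step inside the usual scatter. Compound 2 is further off, with a number 14 percentage points lower from compound 2 to compound 3 (beyond the scatter), a step beyond the scatter.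

Compound 4 `CC1CCN(c2c(S(=O)(=O)c3cccc(C#N)c3)cnc3ccc(F)cc23)CC1` differs from compound 3 in one place: cyano in place of fluoro on an aromatic carbon.

Among the measured compounds shown here, two measured steps bear on this change. The swap of the whole aryl group from compound 1 to compound 3 gave a number 7 percentage points higher from compound 1 to compound 3 (within the scatter), nothing beyond the scatter. The swap on the same aromatic carbon from compound 2 to compound 3 gave a number 14 percentage points lower from compound 2 to compound 3 (beyond the scatter), so an acceptor-bearing group in that place sat on the higher side. Cyano, like methoxy, brings one hydrogen-bond acceptor, so the expectation for compound 4 is a small rise or no change beyond the scatter, that is a number 6 percentage points higher from compound 3 to compound 4 (within the scatter) is expected.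

Compound 4 is therefore estimated at 82% in this assay, with a range from 66% to 95%.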

Compound 4, a percentage reported as inhibition, at one concentration (the size of the read-out at that concentration, not a potency): 93%
Compound 4: the middle estimate sits 11 percentage points below what was measured, and the stated range covers the measured number.
By their numbers in this assay, from the lowest: compounds 1 and 3 (each within the scatter of the next); then compounds 2 and 4 (each within the scatter of the next).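

In this assay, cyano on this aromatic carbon gives a number 17 percentage points higher from compound 3 to compound 4 (beyond the scatter), and against methoxy it gives a number 3 percentage points higher from compound 2 to compound 4 (within the scatter), so fluoro now stands clear below two different groups at this place, and cyano and methoxy cannot be told apart. The earlier compounds shown here showed such a rise with methoxy alone; it is now seen with a second group. Against the 3,5-dichlorophenyl group there is a number 24 percentage points higher from compound 1 to compound 4 (beyond the scatter), so 3-cyanophenyl joins 3-methoxyphenyl beyond the scatter of compound 1, where 3-fluorophenyl stayed within it, and no measurement on hand accounts for this split among the aryl groups.

As far as these compounds go, whether a group such as an amine, a carboxylic acid or a longer chain on this aromatic carbon would hold the level of compound 2 and compound 4 remains open. With a single tested concentration, the read-out also leaves open how compound 2 and compound 4 would compare in potency across a range of concentrations.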